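Chloro to hydrogen on the pendant phenyl of two cores

The compounds below may be only part of what the source reports. "The series", "measured", "known", "first", "only" and "open" are said of these compounds alone.

Compound 1 `COc1ccc(-c2nc(C)c(C(=O)CSc3nc(N)c(C#N)c(-c4ccc(Cl)cc4)n3)s2)cc1` gives 44% in a functional assay on U-87MG ATCC cells for antiproliferative activity against U-87 MG (Homo sapiens), read by MTT assay, with a stated time of 48 h, tested at 10 uM; a lower number here means a stronger effect, a higher number a weaker effect of the compound at the concentration tested. Compound 2 `COc1ccc(-c2nc(C)c(C(=O)CSc3nc(N)c(C#N)c(-c4ccccc4)n3)s2)cc1` gives 57.8% in this assay. The change from compound 1 to compound 2 is hydrogen in place of chloro on an aromatic carbon, and it made the step of a number 13.8 percentage points higher from compound 1 to compound 2 (beyond the scatter). Compound 3 `Cc1nc(-c2ccc(Cl)cc2)sc1C(=O)CSc1nc(-c2ccc(Cl)c(Cl)c2)c(C#N)c(=O)[nH]1`, built on a different core, gives 97.1% in this assay; the difference between the two cores is not broken down here. Compound 4 `Cc1nc(-c2ccccc2)sc1C(=O)CSc1nc(-c2ccc(Cl)c(Cl)c2)c(C#N)c(=O)[nH]1` carries the same change, (hydrogen in place of chloro on an aromatic carbon), at the same place on the ring as in compound 2. The expected step here is a number 1.9 percentage points higher from compound 3 to compound 4 (within the scatter), smaller than the earlier one, because compound 3 already gives 97.1% in this assay and the read-out has little room to rise further. Compound 4 is therefore estimated at 99% in this assay, within 86% to 110%.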

Compound 4, a percentage reported as activity, at one concentration (the size of the read-out at that concentration, not a potency): 92.5%
Compound 4: middle estimate off by 6.5 percentage points, on the high side, within the range that was stated.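

In this assay, 4-chlorophenyl to phenyl on the core of compound 3 gives a number 4.6 percentage points lower from compound 3 to compound 4 (within the scatter), so no effect of the change can be claimed on this core. The change does not carry over at a constant size between these two cores: the same change on two cores in this assay, a number 13.8 percentage points higher (beyond the scatter) from compound 1 to compound 2 and a number 4.6 percentage points lower (within the scatter) from compound 3 to compound 4, 18.4 percentage points apart, beyond the scatter of two such steps These two pairs do not show why the steps differ, and they do not show how the change would behave on any further core.

Still open, on these data alone, is whether an amine or a carboxylic acid in place of chloro on this aromatic carbon would shift the read-out on either core. Also open, as far as these compounds go, is whether such a group would separate the two cores more clearly than hydrogen does.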